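A few compounds are considered here, and "the series" means these few. Any claim that something is new, unique, unknown or untested is made for them only; others in the source may bear on it.

The study contains two measured compounds on different scaffolds. Compound 1 `COc1ccc2cc(CCCOCCCc3cccnc3)oc(=O)c2c1` gives, in a functional assay on 786-0 cells (Homo sapiens) for antiproliferative activity, read by sulforhodamine B assay, with a stated time of 48 h (a higher number here means a weaker inhibitor of growth, a lower number a stronger inhibitor of growth), a reading of 28.7 ug/mL. Compound 2 `O=C1OC(CO)Cc2ccccc21` is a much smaller fragment with a hydroxymethyl group. In this assay compound 2 reaches only a limit of the assay, >= 250 ug/mL, which is the same point as the limit of >= 250 ug/mL in this assay, at which 1 of the 2 values shown sits. So compound 2 stands at the weak end of the numbers shown, with no number of its own.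

The step from compound 2 to compound 3 `COc1ccc2c(c1)C(=O)OC(CO)C2` is a single change: methoxy in place of hydrogen on an aromatic carbon. Among the compounds with values here, no measured pair in the set shows what such a change does. The step of a number no higher from compound 2 to compound 3 (the limit leaves the size open) is therefore expected to be none beyond the usual scatter, with compound 3 most likely staying at the same limit. Compound 3 is estimated in this assay at 250 ug/mL, within a range of 80 ug/mL to 400 ug/mL.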

Compound 3, concentration for 50% growth inhibition: >= 250 ug/mL
Compound 3 ended at the assay's limit (the forecaster's own chance of this, stated with the estimate: 75%); the middle value lies on the limit itself.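

Compound 2 and compound 3 both stand at the same limit, so no step between them can be read: the limit of >= 250 ug/mL in this assay, at which 2 of the 3 values shown sit.

The compounds shown leave open whether methoxy in place of hydrogen on an aromatic carbon changes the reading in this assay at all.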